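Trading the Carboxylic Acid of Compound 1 for Hydroxymethyl

The compounds below may be only part of what the source reports. "The series", "measured", "known", "first", "only" and "open" are said of these compounds alone.

Measured compounds:
Compound 1 `CCCCN(c1nc2c(C(=O)O)cccc2o1)[C@H](C)c1ccc(-c2ccccc2-c2nnn[nH]2)cc1` gives 8.2% in an ADME assay on the whole organism (Macaca fascicularis) for pharmacokinetics, read by LC-MS, using cassette dosing; on this read-out higher numbers stand for higher oral bioavailability and lower numbers for lower oral bioavailability.
Compound 2 `C[C@H](c1ccc(-c2ccccc2-c2nc(=O)o[nH]2)cc1)N(CC1CC1)c1nc2c(C(=O)O)cccc2o1` gives 60% in this assay.

Of the two numbers, compound 1 stands lowest; compound 2 lies higher by a margin beyond the scatter, but the two differ in several places at once, so their gap shows only that both levels occur within this series. Compound 3 `CCCCN(c1nc2c(CO)cccc2o1)[C@H](C)c1ccc(-c2ccccc2-c2nnn[nH]2)cc1` differs from compound 1 in one place: hydroxymethyl in place of carboxy on an aromatic carbon. For the measured compounds named here, no pair of measured compounds isolates this change, and the expectation for compound 3 therefore rests on compound 1 alone and carries a wide range. The step of a number 16.8 percentage points higher from compound 1 to compound 3 (beyond the scatter) is expected to be upward and to exceed the scatter, though with little confidence. Compound 3 is estimated at 25%, within 5% to 55%.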

Compound 3, oral bioavailability: 0.8%
The estimate for compound 3 lay 24.2 percentage points above the measured number; measured number outside the range, below it.
By their numbers in this assay, from the lowest: compounds 3 and 1 (each within the scatter of the next); then compound 2.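

Hydroxymethyl in place of carboxy on this aromatic carbon gives a number 7.4 percentage points lower from compound 1 to compound 3 (within the scatter) in this assay, the first step in which this position is the only thing that differs. On the background of compound 1, this exchange therefore yields no difference in oral bioavailability that can be told from the scatter, so this pair gives no sign that carboxy and hydroxymethyl part ways at this place on this read-out. Nothing at hand gives a measured property that could account for this result.

The compounds shown leave open whether a primary amide, a methyl ester or an aminomethyl group at this position would read the same way. They also leave open whether hydroxymethyl in place of carboxy would give a similar step on the background of compound 2 , where the number is far from the floor of this read-out.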